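The compounds below may be only part of what the source reports. "The series", "measured", "known", "first", "only" and "open" are said of these compounds alone.

Working notes on the series. Compound 1 `N#CC1=C(N)Oc2c(N)cc3nc4ccccc4nc3c2C12C(=O)N(Cc1cnnn1-c1cccc(Br)c1)c1ccccc12` in a functional assay on HepG2 cells (Homo sapiens) for antiproliferative activity, read by MTT assay, with a stated time of 48 h (on this read-out higher numbers stand for weaker inhibition and lower numbers for stronger inhibition), gives > 50000 nM, which is a limit of the assay and not a number. Compound 2 `N#CC1=C(N)Oc2c(N)cc3nc4ccccc4nc3c2C12C(=O)N(Cc1cnnn1-c1ccccc1Br)c1ccccc12` gives 38000 nM in this assay, and the step of an at least 1.3-fold lower number from compound 1 to compound 2 (0.11 log units; that floor lies within the scatter) is small. Compound 3 `CCc1cccc(C)c1-n1nncc1CN1C(=O)C2(C(C#N)=C(N)Oc3c(N)cc4nc5ccccc5nc4c32)c2ccccc21` in this assay gives > 50000 nM, again a limit of the assay. Accordingly compound 3 stands only as a limit; the step of an at least 1.3-fold higher number from compound 2 to compound 3 (0.11 log units; that floor lies within the scatter) has a floor within the scatter, and the step that the two limits leave unreadable from compound 1 to compound 3 cannot be read, given that (the limit of > 50000 nM in this assay, at which 2 of the 3 values shown sit).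

Compound 4 `COc1cc(-n2nncc2CN2C(=O)C3(C(C#N)=C(N)Oc4c(N)cc5nc6ccccc6nc5c43)c3ccccc32)c(OC)cc1Cl` differs from compound 3 by 4-chloro-2,5-dimethoxyphenyl in place of 2-ethyl-6-methylphenyl on an aromatic nitrogen. All three measured steps change the group on the same aromatic nitrogen, and none of them reaches beyond the scatter or beyond the limit, so no step beyond the scatter is expected in this assay from this exchange either. Compound 4 is therefore expected to give about 45000 nM, within 20000 nM to 120000 nM. The expected step is an at least 1.1-fold lower number from compound 3 to compound 4 (0.04 log units; that floor lies within the scatter), with a real chance that only a limit is reported.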

Compound 4, half-maximal inhibitory concentration: > 50000 nM
Compound 4 was reported as a limit; the forecaster's own chance of this, stated with the estimate: 55%; middle value at least 1.1-fold (0.04 log units) from the limit.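

In this assay compound 4 stands only as a limit of the assay, so a 4-chloro-2,5-dimethoxyphenyl group, which unlike the carbon-only 2-ethyl-6-methylphenyl group carries hydrogen-bond acceptors, gives no readable value on this aromatic nitrogen. Among these compounds, the only step that can be read is an at least 1.3-fold higher number from compound 2 to compound 4 (0.11 log units; that floor lies within the scatter), while the steps from compound 3 and from compound 1 to compound 4 cannot be read. The change of substituent type therefore brings no step beyond the scatter, and the series stays pressed against one ceiling: the limit of > 50000 nM in this assay, at which 3 of the 4 values shown sit.

From the compounds shown here alone, whether a phenyl group carrying an amine or a carboxylic acid, or a longer chain in place of the phenyl group, would give a readable value in this assay stays open. How far compound 1, compound 3 and compound 4 lie from one another also stays open: only limits are shown for them.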